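Notes on the Benzyl Swap from Compound 3 to Compound 4

The source may hold more compounds than are shown below. What is called first, only, known or untested is meant among the compounds shown, and "the series" means these compounds.

Compound 1 `C#CCOc1ccc(/C=C/C(=O)c2ccc(Br)cc2)cc1` gives 34% in a functional assay on A549 cells (Homo sapiens) for inhibition, read by MTT assay, with a stated time of 48 h, tested at 10 uM; a higher number here means more inhibition of growth at the concentration tested, a lower number less inhibition of growth. Compound 2 `C#CCOc1ccc(/C=C/C(=O)c2ccc(OC)cc2)cc1` gives 27%, the step being a number 7 percentage points lower from compound 1 to compound 2 (within the scatter). Compound 3 `O=C(/C=C/c1ccc(OCc2cn(Cc3cccc(Br)c3)nn2)cc1)c1ccc(Br)cc1` gives 44%; its gap to compound 1 stays within the scatter, while its gap to compound 2 lies beyond it. Compound 4 `O=C(/C=C/c1ccc(OCc2cn(Cc3ccc(F)cc3)nn2)cc1)c1ccc(Br)cc1` differs from compound 3 by 4-fluorophenyl in place of 3-bromophenyl on a saturated chain carbon bound to an aromatic nitrogen. Going by the values given here, no measured step touches the benzyl bound to the aromatic nitrogen; the only step on record, a halogen-to-methoxy swap on another aromatic carbon, stayed within the scatter. For compound 4 the step of a number 2 percentage points lower from compound 3 to compound 4 (within the scatter) is therefore expected to stay within the scatter. The expected value for compound 4 in this assay is 42%, with a range from 26% to 58%.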

Compound 4, percent growth inhibition at one concentration: 43%
Estimate against measurement, compound 4: 1 percentage points below, within the range that was stated.
By their numbers in this assay, from the lowest: compounds 2, 1, 4 and 3 (each within the scatter of the next, the first and the last beyond it).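

On the saturated chain carbon bound to an aromatic nitrogen, 4-fluorophenyl in place of 3-bromophenyl gives a number 1 percentage points lower from compound 3 to compound 4 (within the scatter) in this assay. This place therefore tolerates this one exchange without a change beyond the scatter. The swap alters both the halogen and its ring position, so the two contributions cannot be separated. Nothing available bears on why the number holds.

Still open, as far as these compounds go, is whether an amine or a carboxylic acid on the phenyl ring, or a longer chain in place of the benzyl, would also stay within the scatter.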